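A few compounds are considered here, and "the series" means these few. Any claim that something is new, unique, unknown or untested is made for them only; others in the source may bear on it.

Measured compounds:
compound 1 `O=C(O)COc1cccc(C[C@@H]2CCCC3OC32c2nc(-c3ccccc3)c(-c3ccccc3)o2)c1`: 14 nM
compound 2 `O=C(O)COc1cccc(C[C@@H]2CCCC(O)=C2c2nc(-c3ccccc3)c(-c3ccccc3)o2)c1`: 116 nM

In a functional assay for inhibition, with Homo sapiens as the target (on this read-out lower numbers stand for stronger inhibition and higher numbers for weaker inhibition), compound 1 gives 14 nM, the lowest of the two numbers. Compound 2 gives 116 nM, a gap beyond the scatter. Compound 3 `O=C(O)COc1cccc(C[C@@H]2CCC[C@H]3O[C@]23c2nc(-c3ccccc3)c(-c3ccccc3)o2)c1` is the next compound to be run. Its difference from compound 1: the two compounds have the same atoms and bonds; at least one stereo element is drawn with a configuration in one of them and without one in the other: 2 of 3 stereo elements differ; a stereocentre at a saturated ring carbon is drawn without a configuration in compound 1 and R in compound 3; a stereocentre at a saturated ring carbon is drawn without a configuration in compound 1 and R in compound 3. Within the data shown here, no step between measured compounds matches this change, so no direction can be read from the set; a step within the scatter or a modest move toward lower numbers is expected. Compound 3 is estimated at 10 nM, range 4 nM to 30 nM. The expected step is a 1.4-fold lower number from compound 1 to compound 3 (0.15 log units; within the scatter).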

Compound 3, half-maximal inhibitory concentration: 5.8 nM
Beside the measured number, compound 3's estimate is 1.7-fold (0.24 log units) above it; the range from low to high includes it.
By their numbers in this assay, from the lowest: compound 3; then compound 1; then compound 2.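

In this assay, with atoms and bonds unchanged, the drawn configuration at two saturated ring carbons accompanies a 2.4-fold lower number from compound 1 to compound 3 (0.38 log units; beyond the scatter). Among these compounds, this is the first sign that stereochemistry at these carbons alone can move the number, although the step is modest. Its reading is limited, because the comparison rests on a defined drawing against an undefined one: the fact that one of compounds 1 and 3 is drawn with a defined configuration and the other without, at the place where they differ

The compounds shown leave open how the opposite configuration at these two ring carbons would read. Also open, as far as these compounds go, is whether an amide in place of the carboxylic acid would keep the number low in this assay.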